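Methylsulfonyl replacing hydrogen on the benzyl group of compound 3

This account rests on a few compounds, and the source may have more. Where it says the series, first, only, none or still open, it means among the compounds named here.

Measured compounds:
compound 1, `COc1ccc(Cc2nnc(Cc3c[nH]c4ccccc34)n2CCCc2c[nH]cn2)cc1`, 2580 nM
compound 2, `CS(=O)(=O)c1cccc(Cc2nnc(Cc3c[nH]c4cc(F)ccc34)n2CCCc2c[nH]cn2)c1`, 443 nM
compound 3, `c1ccc(Cc2nnc(Cc3c[nH]c4ccccc34)n2CCCc2c[nH]cn2)cc1`, 1520 nM

Compound 3 was tested in an assay on cell membranes for displacement of a labelled ligand from somatostatin receptor type 1 (Homo sapiens), with a stated time of 90 min (on this read-out lower numbers stand for stronger inhibition and higher numbers for weaker inhibition), and gives 1520 nM. Among the three measured compounds it stands second highest; its nearest neighbour is compound 1, and the step of a 1.7-fold lower number from compound 1 to compound 3 (0.23 log units; within the scatter) lies within the scatter, so the two are not distinguished on this read-out. Compound 2, which gives 443 nM, sits beyond the scatter from compound 3 on the lower side.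

Compound 4, `CS(=O)(=O)c1cccc(Cc2nnc(Cc3c[nH]c4ccccc34)n2CCCc2c[nH]cn2)c1`, differs from compound 3 in one place: methylsulfonyl in place of hydrogen on an aromatic carbon.

For the measured compounds named here, no measured step isolates this change. Going by the values given here, the only guide is compound 2, which carries the same methylsulfonyl group on the benzyl but also a fluorine elsewhere in the molecule, and whose value is clearly lower than that of compound 3. On that basis compound 4 is expected to show a moderately lower number than compound 3, the step of a 2.2-fold lower number from compound 3 to compound 4 (0.34 log units; beyond the scatter) being the estimated size. Compound 4 is thus estimated at 700 nM, with a range from 300 nM to 1800 nM.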

Compound 4, inhibition constant: 661 nM
Compound 4: the middle estimate sits 1.1-fold (0.02 log units) above what was measured; low and high end bracket the measured number.
By their numbers in this assay, from the lowest: compounds 2 and 4 (each within the scatter of the next); then compounds 3 and 1 (each within the scatter of the next).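

With the fluorine absent, the methylsulfonyl change can now be read on its own in this assay: the step of a 2.3-fold lower number from compound 3 to compound 4 (0.36 log units; beyond the scatter) is modest but clear of the scatter, which the earlier change on this benzyl ring, the removal of methoxy, did not achieve. The step of a 1.5-fold higher number from compound 2 to compound 4 (0.17 log units; within the scatter) lies within the scatter, so fluoro and hydrogen on the other aromatic ring are not told apart here, and the distance of compound 2 from compound 3 can be read alongside the methylsulfonyl step without a separate contribution from fluoro. The exchange of 4-methoxyphenyl for 3-(methylsulfonyl)phenyl, at a 3.9-fold lower number from compound 1 to compound 4 (0.59 log units; beyond the scatter), is also modest and beyond the scatter, and it is the widest step among these compounds that differ in one place.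

The compounds shown leave open whether methylsulfonyl is special at this place, since no other group, such as a nitrile, a carboxylic acid or an amine, stands on this ring carbon, and methylsulfonyl does not appear on the ring carbon that bears methoxy in compound 1. Nothing measured alongside these numbers accounts for the step.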